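Removing the fluoro from compound 1

The source may report more compounds than this note shows. Statements on the series, on what has been measured and on what is new or still open speak of the compounds shown alone.

Measured compounds in an assay on isolated protein for binding affinity to Leucine-rich repeat serine/threonine-protein kinase 2 variant G2019S (Homo sapiens), read by TR-FRET and LanthaScreen, with a stated time of 2 h; a lower number here means a stronger inhibitor, a higher number a weaker inhibitor:
compound 1, `Cn1c(NCc2ccccc2F)c(C#N)c2c(N)ncnc21`, with 120 nM
compound 2, `C[C@H]1CCCN1c1c(C#N)c2c(N)ncnc2n1C`, with 212 nM
compound 3, `Cn1c(-c2ccccc2)c(C#N)c2c(N)ncnc21`, with 33 nM

Compound 1 gives the second highest of the three numbers. Compound 2 gives a number within the scatter of compound 1, so nothing separates them. Compound 3 gives a lower number than compound 1, and that gap lies beyond the scatter.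

Compound 4, `Cn1c(NCc2ccccc2)c(C#N)c2c(N)ncnc21`, is not yet measured. Its difference from compound 1 is hydrogen in place of fluoro on an aromatic carbon. Going by the values given here, the only measured step, a 6.4-fold lower number from compound 2 to compound 3 (0.81 log units; beyond the scatter), exchanges a whole group on the shared core and does not touch a fluoro, so no measured step bears on this change directly. The data hold nothing that shows a fluoro on this ring mattering in this assay. Compound 4 is therefore expected to give a number within the scatter of compound 1, a step of a 1.3-fold higher number from compound 1 to compound 4 (0.10 log units; within the scatter). The estimate for compound 4 is 150 nM, with a range from 55 nM to 420 nM.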

Compound 4, inhibition constant: 243 nM
Estimate against measurement, compound 4: 1.6-fold (0.21 log units) below; measured number inside the range.
By their numbers in this assay, from the lowest: compound 3; then compounds 1, 2 and 4 (each within the scatter of the next, the first and the last beyond it).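

In this assay, going by these compounds alone, the change from 2-fluorophenyl to phenyl gives a 2.0-fold higher number from compound 1 to compound 4 (0.31 log units; beyond the scatter), the first sign in these compounds that a single atom at this place, on an aromatic carbon ortho to a large group, can be read in the assay. The step is modest and only just clears the scatter, but its direction favours keeping the fluoro over hydrogen, so this position is not indifferent to the change. Nothing available explains the step.

The compounds shown leave open whether a chloro or a methyl in the same place would match the fluoro, and whether a fluoro elsewhere on this ring would count as well. They also leave open whether the same exchange on the phenyl of compound 3 would give a step of like size.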